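Pyrazole nitrogen substitution in an oxadiazole Mer inhibitor series

A few compounds are considered here, and "the series" means these few. Any claim that something is new, unique, unknown or untested is made for them only; others in the source may bear on it.

Measured so far:
compound 1 `Cc1nn(C)c(C)c1-c1ccc(-c2nnc(N(C)Cc3ccc4nccn4c3)o2)c(F)c1` 12.6 nM
compound 2 `Cc1cc(-c2c(C)n[nH]c2C)ccc1-c1nnc(N(C)Cc2ccc3nccn3c2)o1` 39.8 nM

In an assay on isolated protein for inhibition of tyrosine-protein kinase Mer (Homo sapiens), read by LC-MS (a lower number here means a stronger inhibitor, a higher number a weaker inhibitor), compound 2 gives the higher of the two numbers; the nearest neighbour, compound 1, gives 12.6 nM, a gap beyond the usual scatter. The two structures differ in more than one place, so the gap is recorded without comment on its origin.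

Compound 3 `Cc1cc(-c2c(C)nn(C(F)F)c2C)ccc1-c1nnc(N(C)Cc2ccc3nccn3c2)o1` departs from compound 2 by one change: difluoromethyl in place of hydrogen on an aromatic nitrogen of the pyrazole ring. Within the data shown here, no measured pair isolates this change, so the expected step in this assay rests only on the two values at hand. A small step toward a lower number is expected, not clearly beyond the scatter, and the estimate for compound 3 is 25 nM with a range of 8 nM to 80 nM, corresponding to an expected step of a 1.6-fold lower number from compound 2 to compound 3 (0.20 log units; within the scatter).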

Compound 3, half-maximal inhibitory concentration in the tyrosine-protein kinase Mer assay: 501 nM
For compound 3 the middle estimate is 20-fold (1.30 log units) below the measured one, and the stated range ends below it.
By their numbers in the tyrosine-protein kinase Mer assay, from the lowest: compound 1; then compound 2; then compound 3.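

The nitrogen of the pyrazole ring is a sensitive position in this series: in the tyrosine-protein kinase Mer assay, difluoromethyl in place of hydrogen on this aromatic nitrogen gives a 13-fold higher number from compound 2 to compound 3 (1.10 log units; beyond the scatter). In the tyrosine-protein kinase Mer assay compound 2 gives 39.8 nM and compound 3 gives 501 nM. Among these compounds, this is the first pair to isolate a change at this position, and it shows that substitution here can carry a large penalty on the shared core. In a physicochemical assay for lipophilicity, at pH 7.4 (on this read-out higher numbers stand for higher lipophilicity and lower numbers for lower lipophilicity), compound 2 gives 3.8 and compound 3 gives 4.1. In the physicochemical assay, the same change gives a number 0.30 log units higher from compound 2 to compound 3 (within the scatter), so the large step in the tyrosine-protein kinase Mer assay comes with no step beyond the scatter in the physicochemical assay, and nothing available accounts for the difference between compound 2 and compound 3.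

From the compounds shown here alone, with one substituent compared against hydrogen, it remains open whether the penalty applies to substitution on this nitrogen in general or to difluoromethyl alone. A longer chain or a chain ending in an amine at this position would help to separate these two readings.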